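The source may report more compounds than this note shows. Statements on the series, on what has been measured and on what is new or still open speak of the compounds shown alone.

Working notes on the series. Compound 1 `O=C1Nc2ccc(S(=O)(=O)N3CCOCC3)cc2/C1=N/NC(=O)c1ccccc1` and compound 2 `O=C1Nc2ccc(S(=O)(=O)N3CCOCC3)cc2/C1=N/NS(=O)(=O)c1ccccc1` share one core and differ only in the group on the amine nitrogen. In a functional assay on HepG2 cells (Homo sapiens) for cytotoxicity, read by sulforhodamine B assay, with a stated time of 24 h (a lower number here means a stronger inhibitor, a higher number a weaker inhibitor), compound 1 gives 18100 nM, and compound 2 gives 23900 nM. Going by the values given here, the one step measured so far, a 1.3-fold higher number from compound 1 to compound 2 (0.12 log units; within the scatter), is small. Compound 2 thus gives the highest of the two numbers in this assay, though the gap to compound 1 lies within the scatter, so no order between the two can be claimed.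

Compound 3 `Cc1ccc(S(=O)(=O)N/N=C2\C(=O)Nc3ccc(S(=O)(=O)N4CCOCC4)cc32)cc1` is next. Its change from compound 2 is methyl in place of hydrogen on an aromatic carbon. Among the compounds with values here, no measured step in this assay touches the phenyl ring of the phenylsulfonyl group, so nothing here tells how a substituent on that ring acts. Within the data shown here, the only step known, from benzoyl to phenylsulfonyl, stayed within the scatter, and a methyl added to a ring that already tolerates such exchange is not expected to move the number beyond the scatter either. The step of a 1.1-fold lower number from compound 2 to compound 3 (0.04 log units; within the scatter) is therefore estimated to be essentially flat. Compound 3 is expected to give about 22000 nM in this assay, with a range from 11000 nM to 45000 nM.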

Compound 3, half-maximal inhibitory concentration: 24700 nM
The estimate for compound 3 lay 1.1-fold (0.05 log units) below the measured number, within the range that was stated.
By their numbers in this assay, from the lowest: compounds 1, 2 and 3 (each within the scatter of the next).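

In this assay, going by these compounds alone, the step of a 1.0-fold higher number from compound 2 to compound 3 (0.01 log units; within the scatter) is the first reading on the ring of the phenylsulfonyl group: methyl in place of hydrogen, para to a large group, stays within the scatter. The step of a 1.4-fold higher number from compound 1 to compound 3 (0.14 log units; within the scatter), with (4-methylphenyl)sulfonyl in place of benzoyl on the amine nitrogen, also stays within the scatter, so compounds 1, 2 and 3 cannot be ordered. No measurement at hand explains the absence of a readable shift at this position.

From the compounds shown here alone, whether an amine, a carboxylic acid or a longer chain at this ring position would give a number beyond the scatter remains open. Also open, going by these compounds, is whether methyl on another carbon of this ring would stay within the scatter in this assay.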